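The source may hold more compounds than are shown below. What is called first, only, known or untested is meant among the compounds shown, and "the series" means these compounds.

Working notes on the series. Compound 2 `Cc1ccc2nc(-c3cccc(OC(F)(F)F)c3)[nH]c(=O)c2c1` carries a trifluoromethoxy group on its pendant ring; compound 1 `Cc1ccc2nc(-c3cccc(C(F)(F)F)c3)[nH]c(=O)c2c1` has trifluoromethyl in place of trifluoromethoxy on an aromatic carbon. In an assay on isolated protein for inhibition of DNA topoisomerase 1 (Homo sapiens), with a stated time of 30 min, tested at 20 uM (on this read-out lower numbers stand for a weaker effect and higher numbers for a stronger effect at the one concentration tested), compound 2 gives 0%, and compound 1 gives 4.2% in the same test; the step of a number 4.2 percentage points higher from compound 2 to compound 1 (within the scatter) is recorded as lying inside the usual scatter, so the two read-outs are not distinguished here. Compound 3 `Cc1ccc2c(=O)[nH]c(-c3cccc(OC(F)(F)F)c3)nc2c1` is built from the same atoms as compound 2, joined differently; the difference between the two cores is not broken down here. In this assay compound 3 gives 0%, level with compound 2 at the digits given, and both sit together at the low end of the three numbers.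

Compound 4 `Cc1ccc2c(=O)[nH]c(-c3cccc(C(F)(F)F)c3)nc2c1` remains to be measured. It differs from compound 3 by trifluoromethyl in place of trifluoromethoxy on an aromatic carbon, which is the same change as from compound 2 to compound 1, at a place described in identical words. For the measured compounds named here, only that one earlier instance is available to rest on, and it stayed within the scatter. The expected step of a number 3 percentage points higher from compound 3 to compound 4 (within the scatter) is therefore set beside a number 4.2 percentage points higher from compound 2 to compound 1 (within the scatter) and kept small. Compound 4 is estimated at 3% in this assay, with a range from 0% to 12%.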

Compound 4, a percentage reported as inhibition, at one concentration (the size of the read-out at that concentration, not a potency): 93.6%
The estimate for compound 4 lay 90.6 percentage points below the measured number, and the stated range ends below it.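

Working notes, continued. In this assay, trifluoromethyl in place of trifluoromethoxy gives a number 93.6 percentage points higher from compound 3 to compound 4 (beyond the scatter), so the change does not carry over as a constant increment between the two cores: the same change on two cores in this assay, a number 4.2 percentage points higher (within the scatter) from compound 2 to compound 1 and a number 93.6 percentage points higher (beyond the scatter) from compound 3 to compound 4, 89.4 percentage points apart, beyond the scatter of two such steps

The result shows that, in these two pairs, the outcome of this one change depends on the core that carries it, and that the step on one core gave no reliable guide to the step on the other. It does not show which difference between the cores is responsible or how the change would behave on any further core, and a read-out at one concentration gives no potency for compound 4.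

From the compounds shown here alone, it remains open whether the high read-out of compound 4 is specific to trifluoromethyl or would also appear with another group at that place, such as a nitrile, a chlorine, an amine or a carboxylic acid. Also open, going by these compounds, is how far it depends on the methyl group of the shared core, which stays unchanged across both pairs.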